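Swapping Fluoro for Chloro in a Cytotoxicity Series

This account rests on a few compounds, and the source may have more. Where it says the series, first, only, none or still open, it means among the compounds named here.

Of the compounds shown here, three sharing one core have been tested in a functional assay on NCI-H460 cells (Homo sapiens) for cytotoxicity, read by MTT assay, with a stated time of 48 h; on this read-out higher numbers stand for weaker inhibition and lower numbers for stronger inhibition. Compound 1 `Cc1ccc2[nH]c(=O)c(-c3nc4cc([N+](=O)[O-])ccc4[nH]3)cc2c1` carries a nitro group on an aromatic carbon, and in this assay compound 1 gives > 100000 nM, which is a limit of the assay rather than a number. Compound 2 `Cc1ccc2[nH]c(=O)c(-c3nc4ccccc4[nH]3)cc2c1` has a hydrogen at the same place, and in this assay compound 2 gives > 100000 nM, again only a limit. Compound 3 `Cc1ccc2[nH]c(=O)c(-c3nc4cc(F)ccc4[nH]3)cc2c1` bears fluoro there, and in this assay compound 3 gives > 100000 nM, also a limit. Because (the limit of > 100000 nM in this assay, at which 3 of the 3 values shown sit), none of the steps between them can be sized: the change from nitro to hydrogen a step that the two limits leave unreadable from compound 1 to compound 2, from nitro to fluoro a step that the two limits leave unreadable from compound 1 to compound 3 and from hydrogen to fluoro a step that the two limits leave unreadable from compound 2 to compound 3 all stay unreadable.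

Compound 4 `Cc1ccc2[nH]c(=O)c(-c3nc4cc(Cl)ccc4[nH]3)cc2c1` has not yet been measured. Its difference from compound 3 is chloro in place of fluoro on an aromatic carbon. The measured steps that bear on this change are the three just named, and all of them are unreadable, so no size can be taken from them. Given (the limit of > 100000 nM in this assay, at which 3 of the 3 values shown sit), compound 4 is expected to stay at the limit as well, and the step from compound 3 to compound 4 is expected to be a step that the limit leaves unreadable from compound 3 to compound 4. Compound 4 is therefore estimated at 150000 nM in this assay, within a range from 50000 nM to 500000 nM, with another limit the most likely outcome.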

Compound 4, half-maximal inhibitory concentration: 36500 nM
Beside the measured number, compound 4's estimate is 4.1-fold (0.61 log units) above it; measured number below the stated range.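

In this assay, among these compounds, compound 4 gives 36500 nM, the first real number in this set, so this position on the six-membered aromatic ring of carbon only can respond to a change of group, which the earlier compounds could not show. Chloro in place of fluoro is an at least 2.7-fold lower number from compound 3 to compound 4 (0.43 log units; beyond the scatter), chloro in place of hydrogen is an at least 2.7-fold lower number from compound 2 to compound 4 (0.43 log units; beyond the scatter), and chloro in place of nitro is an at least 2.7-fold lower number from compound 1 to compound 4 (0.43 log units; beyond the scatter), so chloro stands apart from all three earlier groups by more than the usual scatter. These three sizes are only minimum sizes, and the steps among the three earlier compounds still cannot be read, since each of those compounds has a limit rather than a number: the limit of > 100000 nM in this assay, at which 3 of the 4 values shown sit.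

On these data alone, how far the true gap from chloro to each earlier group extends stays unknown, and with a single readable value no trend across groups can be drawn. A bromo, methyl or methoxy group at the same place would show whether chloro is a lone exception or part of a wider pattern in which other groups also give a readable number.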